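The source may hold more compounds than are shown below. What is called first, only, known or untested is meant among the compounds shown, and "the series" means these compounds.

Compound 1 `c1ccc2c(c1)CC(CCN1CCN(c3cccc4c3OCCO4)CC1)C2` and compound 2 `COc1cc2c(cc1OC)C(CCN1CCN(c3cccc4c3OCCO4)CC1)C2` share one core and differ only in the groups carried on its aromatic ring. In a functional assay on the whole organism for agonist activity, with Rattus norvegicus as the target (a lower number here means that less compound is needed, a higher number that more compound is needed for the effect), compound 1 needs 10 mg/kg. For compound 2 the result in this assay is a limit of the assay rather than a number, > 40 mg/kg, and this is where compound 2 stands (the limit of > 40 mg/kg in this assay, at which 1 of the 2 values shown sits). Compound 3 `COc1ccc2c(c1)C(CCN1CCN(c3cccc4c3OCCO4)CC1)C2` has not yet been measured; it differs from compound 2 by hydrogen in place of methoxy on an aromatic carbon. With one methoxy group removed, compound 3 lies between compound 2 and compound 1 in structure, so in this assay a step toward a lower dose is expected, larger than the usual scatter, though the limit for compound 2 leaves its exact size uncertain. The step expected is an at least 1.6-fold lower number from compound 2 to compound 3 (0.20 log units; that floor lies within the scatter). Compound 3 is estimated to need 25 mg/kg, within a range from 10 mg/kg to 60 mg/kg.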

Compound 3, minimum effective dose: 10 mg/kg
The estimate for compound 3 lay 2.5-fold (0.40 log units) above the measured number, within the range that was stated.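

Until now, compound 2 offered only a limit of the assay, so nothing showed whether the methoxy group at this place made any measurable difference. In this assay the change to hydrogen on this aromatic carbon, ortho to a methoxy group, gives an at least 4.0-fold lower number from compound 2 to compound 3 (0.60 log units; beyond the scatter) and so shows that losing this single methoxy group lowers the dose needed by more than the usual scatter. On these data alone, the true step could be larger than the printed one, and its full size stays unknown because compound 2 is known only as a limit: the limit of > 40 mg/kg in this assay, at which 1 of the 3 values shown sits.

The compounds shown leave open how this position responds to groups other than methoxy and hydrogen, such as hydroxyl, fluorine or the longer ethoxy. They also leave open whether replacing the remaining methoxy group of compound 3 with hydrogen would change the dose needed.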